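The source may report more compounds than this note shows. Statements on the series, on what has been measured and on what is new or still open speak of the compounds shown alone.

Working notes on the series. In an assay on HEK293 cells for displacement of a labelled ligand from NPC1-like intracellular cholesterol transporter 1 (Homo sapiens) (a lower number here means a stronger inhibitor, a higher number a weaker inhibitor), compound 1 `CC(C)(C)c1ccc(C(=O)N2CCC3(CC2)C(=O)N(CC(=O)NCCO)CN3c2ccccc2)cc1` gives 1000 nM, and compound 2 `CC(C)(C)c1ccc(C(=O)N2CCC3(CC2)C(=O)N(CC(=O)NCCCCCO)CN3c2ccccc2)cc1` gives 9400 nM. Within the data shown here, compound 2 thus stands highest of the two numbers measured so far; its nearest neighbour is compound 1, and the only measured step, a 9.4-fold higher number from compound 1 to compound 2 (0.97 log units; beyond the scatter), came with the change to 3-hydroxypropyl in place of hydroxy on a saturated chain carbon, two bonds along the chain from an amide-type nitrogen.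

Compound 3 `CC(C)(C)c1ccc(C(=O)N2CCC3(CC2)C(=O)N(CC(=O)N2CCCC(C(N)=O)C2)CN3c2ccccc2)cc1` is not yet measured. The change from compound 2 to compound 3 is 3-carbamoylpiperidin-1-yl in place of (5-hydroxypentyl)amino on a carbonyl carbon. Among the measured compounds shown here, no measured step covers a ring in place of an open hydroxyalkyl chain, so the single step from compound 1 to compound 2 is the only guide: it shows that lengthening that chain raised the number, and compound 3 drops the chain altogether. On that basis compound 3 is expected to give 3000 nM in this assay, with a plausible range of 700 nM to 15000 nM. That estimate means an expected step of a 3.1-fold lower number from compound 2 to compound 3 (0.50 log units; beyond the scatter), though the direction is uncertain.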

Compound 3, half-maximal inhibitory concentration: 16900 nM
Compound 3: middle estimate off by 5.6-fold (0.75 log units), on the low side; measured number outside the range, above it.
By their numbers in this assay, from the lowest: compound 1; then compounds 2 and 3 (each within the scatter of the next).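

In this assay the change from the open (5-hydroxypentyl)amino to the 3-carbamoylpiperidin-1-yl ring on the carbonyl carbon gives a 1.8-fold higher number from compound 2 to compound 3 (0.25 log units; within the scatter) and so does not separate compound 2 from compound 3, although the entering group brings a six-membered non-aromatic ring and a carbamoyl. Set against the shorter (2-hydroxyethyl)amino, the same ring gives a 17-fold higher number from compound 1 to compound 3 (1.23 log units; beyond the scatter) and thus joins the long chain in standing apart from compound 1, which keeps the lowest number of the three. No supporting data explain these numbers.

The compounds shown leave open whether the ring or the carbamoyl sets the number of compound 3, which a plain piperidin-1-yl and a 3-hydroxypiperidin-1-yl on the same carbonyl carbon could separate. A (3-hydroxypropyl)amino or a (2-aminoethyl)amino would show how the number follows chain length and the hydroxy of compound 1.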